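Carboxy to ethoxycarbonyl on the core of compound 1

The source may report more compounds than this note shows. Statements on the series, on what has been measured and on what is new or still open speak of the compounds shown alone.

Compound 1 `CC1Cc2cccc(-c3ncc(C(=O)O)c(=O)[nH]3)c2O1`: 5 mg/kg
Compound 2 `CCOC(=O)c1cnc(-c2ccccc2OCc2ccccc2)[nH]c1=O`: > 5 mg/kg

Within the data shown here, in a functional assay on the whole organism (strain Sprague-Dawley) for inhibition, with Rattus norvegicus as the target, with a stated time of 10 min (on this read-out higher numbers stand for an effect only at larger amounts of compound and lower numbers for an effect already at smaller amounts), compound 1 gives 5 mg/kg, the only actual number so far. Compound 2 gives > 5 mg/kg, which is a limit of the assay and not a number. Among the measured compounds shown here, no step between these two can be read.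

Compound 3 `CCOC(=O)c1cnc(-c2cccc3c2OC(C)C3)[nH]c1=O` keeps the core of compound 1 and carries ethyl in place of hydrogen on an oxygen next to a carbonyl group, that is, carboxy to ethoxycarbonyl. For the measured compounds named here, the only measured compound with ethoxycarbonyl is compound 2, which stands at the limit > 5 mg/kg, so a shift towards larger doses is expected. The estimated step in this assay is a 2.4-fold higher number from compound 1 to compound 3 (0.38 log units; beyond the scatter), a moderate one. For compound 3 the estimated value is 12 mg/kg, with an expected range of 4 mg/kg to 40 mg/kg. A result reported only as a limit would not be surprising.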

Compound 3, dose for 50% inhibition: 5 mg/kg
Beside the measured number, compound 3's estimate is 2.4-fold (0.38 log units) above it, and the stated range covers the measured number.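

In this assay the series now has its first readable step, no change at the digits printed from compound 1 to compound 3 (within the scatter), for ethyl in place of hydrogen on an oxygen next to a carbonyl group. On the core of compound 1, the free carboxy group is therefore not needed for a measured dose, and carboxy and ethoxycarbonyl cannot be told apart on this read-out. Compound 2 gives > 5 mg/kg, which is a limit of the assay and not a number, and it remains the only such result: the limit of > 5 mg/kg in this assay, at which 1 of the 3 values shown sits.

Among these compounds, no step to compound 2 can be read. On these data alone, whether a longer chain such as butyl on the same oxygen, or a primary amide in place of the ester, would keep the dose on this core remains open.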